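A few compounds are considered here, and "the series" means these few. Any claim that something is new, unique, unknown or untested is made for them only; others in the source may bear on it.

Measured in a functional assay on BGC-823 cells (Homo sapiens) for antiproliferative activity, read by MTT assay, with a stated time of 48 h; a higher number here means a weaker inhibitor, a lower number a stronger inhibitor:
- Compound 1 `Fc1cccc(F)c1CSc1nnc(-c2cnccn2)o1`: > 50000 nM
- Compound 2 `c1ccc(CSc2nnc(-c3cnccn3)o2)cc1`: 25000 nM
- Compound 3 `Brc1ccccc1CSc1nnc(-c2cnccn2)n1-c1ccccc1`: 36200 nM

Compound 1 has the entry > 50000 nM, which is a limit of this assay and not a number. Compound 3, at 36200 nM, lies within the scatter of compound 2, at 25000 nM. Compound 4 `Fc1cccc(F)c1CSc1nnc(-c2cnccn2)n1-c1ccccc1` has not yet been measured. It carries 2,6-difluorophenyl in place of 2-bromophenyl on a saturated chain carbon bound to a sulfur. Among the measured compounds shown here, no pair of measured compounds shows the size of this change, so no shift beyond the scatter is expected in this assay. The expected step of a 1.0-fold higher number from compound 3 to compound 4 (0.02 log units; within the scatter) is therefore small. Compound 4 is estimated at 38000 nM, with an expected range of 16000 nM to 70000 nM.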

Compound 4, half-maximal inhibitory concentration: > 50000 nM
Compound 4 ended at the assay's limit; the forecaster's own chance of this, stated with the estimate: 35%; at least 1.3-fold (0.11 log units) between middle value and limit.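

Compound 4 gives > 50000 nM, which is a limit of the assay and not a number. In this assay, among the compounds shown here, 2,6-difluorophenyl in place of 2-bromophenyl on a saturated chain carbon bound to a sulfur gives an at least 1.3-fold higher number from compound 3 to compound 4 (0.14 log units; that floor lies within the scatter), the first step that can be read at this position, and it brings no lower number. The floor of that step does not give its real size: the limit of > 50000 nM in this assay, at which 2 of the 4 values shown sit.

Going by these compounds, how far the true value of compound 4 lies past the limit stays open. Also open, on these data alone, is whether an amine or a carboxylic acid on the same saturated chain carbon would bring the number down.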